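The compounds below may be only part of what the source reports. "The series", "measured", "known", "first", "only" and "open" are said of these compounds alone.

In an in vitro assay on BL21-DE3 cells for displacement of a labelled ligand from thyroid hormone receptor beta (Homo sapiens), read by fluorescence polarization (on this read-out lower numbers stand for stronger inhibition and higher numbers for weaker inhibition), compound 3 `C#CC(=O)Nc1ccc(CCCCCC)cc1` gives 35100 nM, the higher of the two numbers reported. Compound 1 `C/C=C/C(=O)c1ccc(CCCCCCC)cc1` gives 7600 nM, a clearly lower number. Compound 2 `CCCCCCc1ccc(NC(=O)C=C(C)C)cc1` returns only a limit of the assay, > 100000 nM. Within the data shown here, the one measured step is an at least 2.8-fold lower number from compound 2 to compound 3 (0.45 log units; beyond the scatter), and it counts as at least modest. Compound 4 `CCCCCCc1ccc(C(=O)C2CO2)cc1` differs from compound 3 by (oxiran-2-yl)carbonyl in place of (ethynylcarbonyl)amino on an aromatic carbon. This change both replaces the amide linkage with a ketone, as in compound 1, and exchanges the group on the carbonyl carbon, so the measured step bears on it only loosely. A step of a 2.9-fold lower number from compound 3 to compound 4 (0.47 log units; beyond the scatter) is expected, toward a lower number. Compound 4 is estimated at 12000 nM, most likely between 3000 nM and 50000 nM.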

Compound 4, half-maximal inhibitory concentration: 19100 nM
The estimate for compound 4 lay 1.6-fold (0.20 log units) below the measured number; the measured number falls inside the stated range.
By their numbers in this assay, from the lowest: compound 1; then compounds 4 and 3 (each within the scatter of the next). At a limit, above all of these: compound 2.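

On this aromatic carbon, the swap of (ethynylcarbonyl)amino for (oxiran-2-yl)carbonyl gives a 1.8-fold lower number from compound 3 to compound 4 (0.26 log units; within the scatter) and so does not separate the two compounds. Among these compounds, the amide hydrogen goes and a three-membered ring enters, yet the two numbers stay within the scatter of each other, something the earlier compounds could not show. No measurement shown accounts for this result. Still open, as far as these compounds go, is how this position responds to a group outside this set, such as an amine or a carboxylic acid. Also open, from the compounds shown here alone, is what the ketone and the oxirane each contribute alone, as both change together in this step.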